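This account rests on a few compounds, and the source may have more. Where it says the series, first, only, none or still open, it means among the compounds named here.

Compound 1 `CC(C)=CCc1cc(C(=O)Nc2cc3ccc(OCC4CCN(C)C4)c(C)c3oc2=O)ccc1O`: 920 nM
Compound 2 `CC(C)=CCc1cc(C(=O)Nc2cc3ccc(OCCCN4CCCC4)c(C)c3oc2=O)ccc1O`: 720 nM

Both values come from a functional assay on SK-BR-3 cells (Homo sapiens) for antiproliferative activity; a lower number here means a stronger inhibitor, a higher number a weaker inhibitor. For the measured compounds named here, compound 2 cannot be separated from compound 1, the only other measured compound, as the step between them is a 1.3-fold lower number from compound 1 to compound 2 (0.11 log units; within the scatter). Compound 3 `CCN(C)CCCOc1ccc2cc(NC(=O)c3ccc(O)c(CC=C(C)C)c3)c(=O)oc2c1C` differs from compound 2 in one group: ethyl(methyl)amino in place of pyrrolidin-1-yl on a saturated chain carbon, three bonds along the chain from an oxygen on an aromatic ring. Put simply, ethyl(methyl)amino stands in place of pyrrolidin-1-yl on a saturated chain carbon, three bonds along the chain from an oxygen on an aromatic ring. Going by the values given here, no measured step makes this exact exchange. Among the compounds with values here, the closest evidence is the single change to the same side chain that links compound 1 to compound 2, a 1.3-fold lower number from compound 1 to compound 2 (0.11 log units; within the scatter), so no step beyond the scatter is expected in this assay. The expected step is a 1.0-fold higher number from compound 2 to compound 3 (0.02 log units; within the scatter). Compound 3 is estimated at 750 nM, with an expected range of 350 nM to 1600 nM.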

Compound 3, half-maximal inhibitory concentration: 730 nM
Compound 3: middle estimate off by 1.0-fold (0.01 log units), on the high side; the measured number falls inside the stated range.
By their numbers in this assay, from the lowest: compounds 2, 3 and 1 (each within the scatter of the next).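

In this assay, replacing the pyrrolidin-1-yl ring with the open-chain ethyl(methyl)amino gives a 1.0-fold higher number from compound 2 to compound 3 (0.01 log units; within the scatter), so at this chain end, a ring around the nitrogen is not required for a value in this range. The change from the 1-methylpyrrolidin-3-yl side chain to 2-(ethyl(methyl)amino)ethyl gives a 1.3-fold lower number from compound 1 to compound 3 (0.10 log units; within the scatter), so this open-chain amine also matches the compound with a differently attached ring. No separate measurement is available to explain this result.

On these data alone, all three side chains still end in a nitrogen carrying three carbon substituents, so it remains open whether a primary amine, a hydroxyl or a carboxylic acid could take its place. It is also unknown how a longer chain between the oxygen and the amine would affect the value.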